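A few compounds are considered here, and "the series" means these few. Any claim that something is new, unique, unknown or untested is made for them only; others in the source may bear on it.

Measured compounds:
compound 1 `Cc1cc(-c2ccccc2)cc(C)c1Oc1cc(N)nc(Nc2ccc(C#N)cc2)n1` — 25600 nM
compound 2 `COc1ccccc1-c1cc(C)c(Oc2cc(N)nc(Nc3ccc(C#N)cc3)n2)c(C)c1` — 21800 nM

In a toxicity assay on MT4 cells (Homo sapiens) for cytotoxicity, read by MTT assay (a higher number here means that more compound is tolerated, a lower number that less compound is tolerated), compound 1 gives 25600 nM, the higher of the two numbers. Compound 2 gives 21800 nM; the step of a 1.2-fold lower number from compound 1 to compound 2 (0.07 log units; within the scatter) lies within the scatter, so the two compounds are not separated by this assay. The unmeasured compound 3 `Cc1cc(-c2ccc(C#N)cc2)cc(C)c1Oc1cc(N)nc(Nc2ccc(C#N)cc2)n1` differs from compound 1 by cyano in place of hydrogen on an aromatic carbon; the same difference, cut one bond further out, reads phenyl to 4-cyanophenyl. Among the measured compounds shown here, the only measured step, from compound 1 to compound 2, also places a substituent on that phenyl, and it stayed within the scatter. Nothing measured speaks for a shift beyond the scatter, so for compound 3 the expected step is a 1.1-fold lower number from compound 1 to compound 3 (0.03 log units; within the scatter). Compound 3 is estimated at 24000 nM, with a range from 10000 nM to 60000 nM.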

Compound 3, half-maximal cytotoxic concentration: 18100 nM
Beside the measured number, compound 3's estimate is 1.3-fold (0.12 log units) above it, and the stated range covers the measured number.
By their numbers in this assay, from the lowest: compounds 3, 2 and 1 (each within the scatter of the next).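

Read in this assay the cyano group, placed on an aromatic carbon of the phenyl para to a large group, gives a 1.4-fold lower number from compound 1 to compound 3 (0.15 log units; within the scatter) and so does not separate the two compounds. This adds a second kind of substituent on that phenyl to the methoxy of compound 2, and the direct comparison of the two substituted phenyls gives a 1.2-fold lower number from compound 2 to compound 3 (0.08 log units; within the scatter) and leaves 4-cyanophenyl and 2-methoxyphenyl unseparated as well. No supporting measurement bears on this result, so the numbers stand without an explanation.

Still open, as far as these compounds go, is whether an amine or a carboxylic acid on this phenyl would give a step beyond the scatter. Also open, from the compounds shown here alone, is whether cyano on another carbon of the same ring would read the same way in this assay.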